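The source may report more compounds than this note shows. Statements on the series, on what has been measured and on what is new or still open speak of the compounds shown alone.

The study sets three compounds on a shared core against one another in a functional assay on L5178Y cells (Mus musculus) for antiproliferative activity; a lower number here means a stronger inhibitor, a higher number a weaker inhibitor. Compound 1 `Nc1nc(=O)n(C2OC(CO)C(Cl)C2O)cc1F` gives 71 ug/mL in this assay. Compound 2 `Nc1ccn(C2OC(CO)C(I)C2O)c(=O)n1` does not give a number in this assay: it reaches only the limit of > 100 ug/mL, and that limit is all that is known of it. Compound 2 therefore stands at the limit of > 100 ug/mL in this assay, at which 1 of the 2 values shown sits, so its true value could lie anywhere beyond that bound. Compound 3 `Nc1ccn(C2OC(CO)C(Cl)C2O)c(=O)n1` has not yet been measured in this assay. It differs from compound 2 in a single place, (chloro in place of iodo on a saturated ring carbon), and no other part of the molecule is touched. Going by the values given here, because no two measured compounds differ in one place, there is no measured step to lean on, and the two values shown say only that compound 1 gives a number while compound 2 gives a limit. The step from compound 2 to compound 3 is expected to be a step that the limit leaves unreadable from compound 2 to compound 3 in this assay, which is within the scatter rather than a clear change in either direction. Compound 3 is estimated to give about 110 ug/mL in this assay, with a range from 40 ug/mL to 300 ug/mL, so a limit rather than a number is a real possibility.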

Compound 3, concentration for 50% inhibition: > 100 ug/mL
Compound 3: only a limit was reported; the forecaster's own chance of this, stated with the estimate: 55%; the middle value is on the limit's open side.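

In this assay compound 3 also reaches only a limit, > 100 ug/mL, so chloro in place of iodo on a saturated ring carbon gives no number on either side, and the step across this change cannot be read. The result does supply the first measured pair differing in one place with a number on one side: hydrogen in place of fluoro on an aromatic carbon is an at least 1.4-fold higher number from compound 1 to compound 3 (0.14 log units; that floor lies within the scatter), so this change cannot be said to exceed the scatter, although the true step may be larger than that floor. The limit now shapes most of what can be read in this assay: the limit of > 100 ug/mL in this assay, at which 2 of the 3 values shown sit.

The compounds shown leave open how far past the limit compound 2 and compound 3 truly lie, and so whether the fluoro group on the aromatic carbon makes a real difference. They also leave open whether a bromo group or an amine on that saturated ring carbon, in place of chloro, would give a number rather than a limit.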